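Replacing the diethylamino side chain of compound 1

This account rests on a few compounds, and the source may have more. Where it says the series, first, only, none or still open, it means among the compounds named here.

In a functional assay on HepG2 cells (Homo sapiens), read by MTT assay, with a stated time of 48 h (on this read-out lower numbers stand for stronger inhibition and higher numbers for weaker inhibition), compound 1 `CCN(CC)CCNC(=O)c1ccc(C(CC)(CC)c2ccc(OCC(=O)C(C)(C)C)c(C)c2)n1CC` gives 620 nM. Compound 2 `CCN(CC)CCCNC(=O)c1ccc(C(CC)(CC)c2ccc(OCC(O)C(C)(C)C)c(C)c2)n1CC` gives 1100 nM, within the scatter of compound 1. Compound 3 `CCn1c(C(=O)N(CCC#N)CCC#N)ccc1C(CC)(CC)c1ccc(OCC(O)C(C)(C)C)c(C)c1` gives 42000 nM, so compound 1 sits far under it.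

Compound 4 `CCn1c(C(=O)N(C)CC(=O)O)ccc1C(CC)(CC)c1ccc(OCC(=O)C(C)(C)C)c(C)c1` differs from compound 1 in one place: (carboxymethyl)(methyl)amino in place of (2-(diethylamino)ethyl)amino on a carbonyl carbon. Here (carboxymethyl)(methyl)amino stands in place of (2-(diethylamino)ethyl)amino on a carbonyl carbon.

Among the compounds with values here, only one measured step bears on this. That step, a 38-fold higher number from compound 2 to compound 3 (1.58 log units; beyond the scatter), also exchanged the group on a carbonyl carbon, lost the diethylamino group and was large. A single step is thin evidence, but a similar upward move is expected here: a 40-fold higher number from compound 1 to compound 4 (1.61 log units; beyond the scatter) in this assay. For compound 4, the estimated value is 25000 nM, with a range of 6000 nM to 100000 nM.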

Compound 4, half-maximal inhibitory concentration: 25200 nM
Estimate against measurement, compound 4: 1.0-fold (0.00 log units) below; the range from low to high includes it.
By their numbers in this assay, from the lowest: compounds 1 and 2 (each within the scatter of the next); then compounds 4 and 3 (each within the scatter of the next).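

In this assay, replacing (2-(diethylamino)ethyl)amino with (carboxymethyl)(methyl)amino gives a 41-fold higher number from compound 1 to compound 4 (1.61 log units; beyond the scatter). This shows that a large rise on losing the diethylamino group is not confined to the hydroxyl-bearing compounds 2 and 3, as it also appears with the ketone-bearing compound 1. No measurement shown explains the rise.

Compound 4 both loses the diethylamino group and gains a carboxylic acid, so the compounds shown cannot separate those two changes on this core. A butylamino group on the same carbonyl carbon, with neither the diethylamino group nor the acid, would help to tell them apart.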